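Pyrazoline Amides on Vero Cells: Toward Compound 4

A few compounds are considered here, and "the series" means these few. Any claim that something is new, unique, unknown or untested is made for them only; others in the source may bear on it.

Three compounds of this series have so far been examined in an ADME assay on Vero cells (Chlorocebus sabaeus) for cytotoxicity, read by MTT assay, with a stated time of 72 h; a higher number here means a weaker inhibitor, a lower number a stronger inhibitor. Compound 1 `O=C(O)c1ccccc1C1CC(c2cc3ccccc3o2)=NN1C(=O)c1ccncc1` reached only a limit in this assay, > 170000 nM. Compound 2 `O=C(c1ccncc1)N1N=C(c2cc3ccccc3o2)CC1c1ccccc1Cl` likewise gave only a limit, > 210000 nM. The step that the two limits leave unreadable from compound 1 to compound 2 therefore cannot be read in size. Compound 3 `CCn1cc(C(=O)N2N=C(c3cc4ccccc4o3)CC2c2ccccc2OC)c(=O)c2ccc(C)nc21` also stopped at a limit in this assay, > 187000 nM. Every value shown is thus a limit rather than a number: the limit of > 170000 nM in this assay, at which 1 of the 3 values shown sits, the limit of > 187000 nM in this assay, at which 1 of the 3 values shown sits, and (the limit of > 210000 nM in this assay, at which 1 of the 3 values shown sits). Compound 3 stands where the other two stand, at a limit with no number beneath it, and no order among the three can be stated.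

Compound 4 `CCn1cc(C(=O)N2N=C(c3cc4ccccc4o3)CC2c2ccc(O)cc2)c(=O)c2ccc(C)nc21` differs from compound 3 in one place: 4-hydroxyphenyl in place of 2-methoxyphenyl on a saturated ring carbon. Going by the values given here, no measured step concerns this change; the only measured step in this assay touches a different place and is itself unreadable. With all three values at limits, neither direction nor size can be drawn from them, and compound 4 is expected to show a step that the limit leaves unreadable from compound 3 to compound 4 that stays within the scatter. Compound 4 is accordingly expected to give 200000 nM in this assay, within 100000 nM to 400000 nM, and most probably once more only a limit.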

Compound 4, half-maximal inhibitory concentration: > 148000 nM
Compound 4 was reported as a limit; the forecaster's own chance of this, stated with the estimate: 85%; the middle value lies beyond the limit too.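

In this assay compound 4 gave only a limit, > 148000 nM. Compound 3 likewise gave only a limit, > 187000 nM. Going by these compounds alone, no step from compound 3 to compound 4 can therefore be read, in size or direction. The compounds shown leave open whether 4-hydroxyphenyl in place of 2-methoxyphenyl changes the value at all, and where any of the four compounds would give an actual number.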